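The compounds below may be only part of what the source reports. "The series", "measured", "known", "first", "only" and "open" are said of these compounds alone.

Measured so far:
Compound 1 `CS(=O)(=O)n1ccc(CN(Cc2ccc(Cl)cc2)Cc2ccc([N+](=O)[O-])s2)c1` — in a functional assay on HEK293 cells for agonist activity at nuclear receptor subfamily 1 group D member 1 (Homo sapiens), read by a luciferase reporter, with a stated time of 24 h (a higher number here means that more compound is needed for the effect, a lower number that less compound is needed), compound 1 gives "not determined" (no result reported).
Compound 2 `CC(=O)N1CCC(CN(Cc2ccc(Cl)cc2)Cc2ccc([N+](=O)[O-])s2)C1` — in this assay compound 2 gives 1600 nM.

For the measured compounds named here, compound 2 thus carries the only number in this assay seen here, and compound 1 stands beside it without a result, so no step between measured compounds can be drawn from these two. Compound 3 `O=C(Nc1ccc([N+](=O)[O-])cc1)N1CCC(CN(Cc2ccc(Cl)cc2)Cc2ccc([N+](=O)[O-])s2)C1` is the untested partner. It differs from compound 2 at one place: (4-nitrophenyl)amino in place of methyl on a carbonyl carbon. The same difference, cut one bond further out, reads acetyl to (4-nitrophenyl)carbamoyl. Going by the values given here, with no measured step to lean on, what is expected of compound 3 rests on this structural change and on the single value of compound 2 alone. The expected step is a 2.0-fold lower number from compound 2 to compound 3 (0.30 log units; within the scatter), a modest move towards less compound being needed, close to the edge of the scatter. Compound 3 is therefore estimated at 800 nM in this assay, within a range from 250 nM to 3000 nM.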

Compound 3, half-maximal effective concentration: 400 nM
For compound 3 the middle estimate is 2.0-fold (0.30 log units) above the measured one; the measured number falls inside the stated range.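

For the compounds shown here, compound 3 gives the first measured step at this place: with (4-nitrophenyl)amino in place of methyl on the carbonyl carbon, this assay shows a 4.0-fold lower number from compound 2 to compound 3 (0.60 log units; beyond the scatter). The step lies beyond the scatter, so this carbonyl carbon, whose other neighbour is an amide-type nitrogen in a ring, can carry a much larger group bearing a six-membered aromatic ring without the number rising, and the number in fact falls. No measurement shown here accounts for this change.

The entering group adds an amino nitrogen, an aromatic ring and a nitro group at once, and this single step cannot divide its size among them. On these data alone, how a plain phenylamino group, a (4-methoxyphenyl)amino group or a simple dimethylamino group would read at this carbonyl carbon remains open.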